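Acetamido in place of hydrogen on compound 2

The compounds below may be only part of what the source reports. "The series", "measured", "known", "first", "only" and "open" are said of these compounds alone.

In a functional assay with Rattus norvegicus as the target (a lower number here means that less compound is needed, a higher number that more compound is needed for the effect), compound 2 `C[C@@H](/N=C(\S)NCc1ccc(C(C)(C)C)cc1)c1ccccc1` gives > 100000 nM, which is a limit and not a number. Compound 1 `C[C@@H](/N=C(\S)NCc1ccc(C(C)(C)C)cc1)c1ccc([N+](=O)[O-])cc1` gives > 100000 nM, also a limit. Compound 3 `C[C@H](/N=C(\S)NCc1ccc(C(C)(C)C)cc1)c1ccccc1` gives > 100000 nM, again a limit. The series thus shows (the limit of > 100000 nM in this assay, at which 3 of the 3 values shown sit), and neither a step that the two limits leave unreadable from compound 1 to compound 2 nor a step that the two limits leave unreadable from compound 2 to compound 3 has a readable size. Compound 4 `CC(=O)Nc1ccc([C@@H](C)/N=C(\S)NCc2ccc(C(C)(C)C)cc2)cc1` carries acetamido in place of hydrogen on an aromatic carbon, para to a large group. Going by the values given here, the nearest precedent is the nitro compound, where a step that the two limits leave unreadable from compound 1 to compound 2 offers no sign of a gain in this assay. The estimated step is a number no higher from compound 2 to compound 4 (the limit leaves the size open), with no direction expected beyond the scatter, and another limit is the likeliest report. For compound 4 the expected value is 100000 nM, with an estimated range of 30000 nM to 300000 nM.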

Compound 4, half-maximal effective concentration: > 100000 nM
Compound 4: no number, only a limit (the forecaster's own chance of this, stated with the estimate: 85%); the middle value lies on the limit itself.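

In this assay compound 4 gives > 100000 nM, a limit and not a number. Neither the step from compound 2 to compound 4 nor the step from compound 1 to compound 4 can be read. The compounds shown leave open whether any of these changes alters the effect at all.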